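Swapping Methyl for 4-Chlorophenyl on a Shared Core

The source may hold more compounds than are shown below. What is called first, only, known or untested is meant among the compounds shown, and "the series" means these compounds.

For the measured compounds named here, in a functional assay on K562 cells (Homo sapiens) for antiproliferative activity, read by MTT assay, with a stated time of 48 h (a higher number here means a weaker inhibitor, a lower number a stronger inhibitor), compound 1 (`CNc1nc(Nc2cnn(CCCCCCC(=O)NO)c2)ncc1Cl`) gives 590 nM as its result, the lower of the two numbers so far and therefore the stronger inhibitor. In this assay compound 2 (`O=C(CCCCCn1cc(Nc2ncc(Cl)c(Nc3ccccc3Cl)n2)cn1)NO`) gives 1810 nM as its result, a gap beyond the usual scatter.

Compound 3 (`O=C(CCCCCCn1cc(Nc2ncc(Cl)c(Nc3ccc(Cl)cc3)n2)cn1)NO`) has not yet been measured. It keeps the rest of compound 1 but carries 4-chlorophenyl in place of methyl on a nitrogen on an aromatic ring, so methylamino becomes (4-chlorophenyl)amino. Going by the values given here, no measured pair isolates this change, so any forecast is uncertain. Among the compounds with values here, the one hint is compound 2, which also has a chlorine-bearing aromatic ring on that nitrogen and gives 1810 nM as its value, although it differs from compound 1 in more than this one place. A modest weakening in this assay is therefore expected, not a large loss. The estimated change is a 2.2-fold higher number from compound 1 to compound 3 (0.34 log units; beyond the scatter) and points toward a higher number. In this assay the estimate for compound 3 is 1300 nM with a range from 400 nM to 4000 nM as the expected span.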

Compound 3, half-maximal inhibitory concentration: 320 nM
For compound 3 the middle estimate is 4.1-fold (0.61 log units) above the measured one; the measured number lies below the stated range.
By their numbers in this assay, from the lowest: compounds 3 and 1 (each within the scatter of the next); then compound 2.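

For the compounds shown here, this is the first pair that differs in one place only, so the effect of this change can now be read directly: in this assay, exchanging the methyl group for 4-chlorophenyl gives a 1.8-fold lower number from compound 1 to compound 3 (0.27 log units; within the scatter) and leaves the two compounds indistinguishable. The position therefore carries either a lone methyl or a much larger group with a six-membered aromatic ring of carbon only, and no loss of antiproliferative activity appears in this cell assay. Nothing available here explains why the two groups give such similar results.

The compounds shown do not separate the contribution of the aromatic ring from that of its chlorine, which a plain phenyl or a 4-fluorophenyl at the same place would begin to do. They also leave open how far this position stretches beyond these two groups, for example to a saturated ring such as cyclohexyl or to a group carrying an amine, such as 4-aminophenyl.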